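Thiophene in place of bromophenyl on a shared guanidine core

This account rests on a few compounds, and the source may have more. Where it says the series, first, only, none or still open, it means among the compounds named here.

Of the compounds shown here, three sharing one core have been measured in a functional assay on Right cardiac atrium for agonist activity at histamine H2 receptor (Cavia porcellus), with a stated time of 30 min, in the presence of a further agent that is not named here; on this read-out lower numbers stand for smaller maximal responses and higher numbers for larger maximal responses. Compound 1 `Cc1nc(N)sc1CCCN/C(N)=N/C(=O)NC(C)c1ccc(Br)cc1` gives 0.87 and stands second highest of the three. Compound 3 `Cc1nc(N)sc1CCCN/C(N)=N/C(=O)NC(c1ccccc1)c1ccccc1` gives 0.9, a value within the scatter of compound 1, so the two cannot be ordered. Compound 2 `Cc1nc(N)sc1CCCN/C(N)=N/C(=S)N[C@@H](C)c1ccccc1` gives 0.65, which lies beyond the scatter below compound 1. The unmeasured compound 4 `Cc1nc(N)sc1CCCN/C(N)=N/C(=O)NC(C)c1cccs1` differs from compound 1 in one place: thiophen-2-yl in place of 4-bromophenyl on a saturated chain carbon bound to an amide-type nitrogen and a saturated chain carbon. Among the measured compounds shown here, no measured pair isolates this change. Compound 3, with a different group at that carbon, gives 0.9, close to compound 1. The expected step is thus a number 0.020 lower from compound 1 to compound 4 (within the scatter), none beyond the scatter. Compound 4 is estimated at 0.85, between 0.7 and 0.97.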

Compound 4, intrinsic activity: the largest response reached, as a fraction of the reference agonist's: 0.88
Compound 4: middle estimate off by 0.030, on the low side; the range from low to high includes it.
By their numbers in this assay, from the lowest: compound 2; then compounds 1, 4 and 3 (each within the scatter of the next).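

Among the compounds shown here, replacing 4-bromophenyl with thiophen-2-yl in this assay gives a number 0.010 higher from compound 1 to compound 4 (within the scatter), the first reading of a single change at this position. The maximal response therefore cannot be told apart when a five-membered aromatic ring with 1 hetero atom replaces the six-membered carbon ring and the bromine is lost. No available evidence bears on why the response holds. Still open, on these data alone, is whether this carbon needs an aromatic ring at all. A cyclohexyl group or a pyridine ring there would test this.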